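Benzyl substituent swap in the rhodanine-acid series

The source may report more compounds than this note shows. Statements on the series, on what has been measured and on what is new or still open speak of the compounds shown alone.

Among the compounds with values here, compound 2 `O=C(O)CN1C(=O)/C(=C/c2nc3ccccc3n2Cc2ccc([N+](=O)[O-])cc2)SC1=S` stands second highest of the three numbers so far, giving 5320 nM in a functional assay on HL-60 cells (Homo sapiens) for cytotoxicity, read by MTT assay, with a stated time of 48 h; a higher number here means a weaker inhibitor, a lower number a stronger inhibitor. Its nearest neighbour is compound 1 `O=C(O)CN1C(=O)/C(=C/c2nc3ccccc3n2Cc2ccc(Br)cc2F)SC1=S` at 6420 nM, with a 1.2-fold lower number from compound 1 to compound 2 (0.08 log units; within the scatter), while compound 3 `O=C(O)CN1C(=O)/C(=C/c2nc3ccccc3n2Cc2ccc(F)cc2)SC1=S` at 1420 nM lies furthest off, with a 3.7-fold lower number from compound 2 to compound 3 (0.57 log units; beyond the scatter).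

Compound 4 `O=C(O)CN1C(=O)/C(=C/c2nc3ccccc3n2Cc2ccccc2F)SC1=S` is not yet measured. It differs from compound 2 as follows: 2-fluorophenyl in place of 4-nitrophenyl on a saturated chain carbon bound to an aromatic nitrogen.

Within the data shown here, two measured steps bear on this change. The step of a 3.7-fold lower number from compound 2 to compound 3 (0.57 log units; beyond the scatter) shows that exchanging nitro for fluoro on the aromatic carbon gave a modest gain; the step of a 4.5-fold lower number from compound 1 to compound 3 (0.66 log units; beyond the scatter) shows that compound 1, which carries the 2-fluorophenyl pattern together with a bromo, sits at the weak end. Compound 4 therefore keeps the fluorine but loses the nitro, and the expected move is a moderate gain, smaller than the step to compound 3, with the possibility of none beyond the scatter.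

For compound 4 the estimate is 3000 nM, expected between 1200 nM and 8000 nM, meaning a 1.8-fold lower number from compound 2 to compound 4 (0.25 log units; within the scatter).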

Compound 4, half-maximal inhibitory concentration: 210 nM
For compound 4 the middle estimate is 14-fold (1.15 log units) above the measured one; the whole stated range lies above it.
By their numbers in this assay, from the lowest: compound 4; then compound 3; then compounds 2 and 1 (each within the scatter of the next).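

In this assay, moving from 4-fluorophenyl to 2-fluorophenyl on a saturated chain carbon bound to an aromatic nitrogen gives a 6.8-fold lower number from compound 3 to compound 4 (0.83 log units; beyond the scatter), and replacing 4-nitrophenyl with 2-fluorophenyl at the same place gives a 25-fold lower number from compound 2 to compound 4 (1.40 log units; beyond the scatter), so the substitution pattern on this benzyl ring matters, not just the presence of a fluoro. Removing the bromo gives a 31-fold lower number from compound 1 to compound 4 (1.49 log units; beyond the scatter), which shows that the 2-fluorophenyl pattern is not itself tied to the weak end of the series, as compound 1 alone might have suggested. No measurement here accounts for either effect.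

Still open, on these data alone, is how plain phenyl, 2-chlorophenyl or 2-methoxyphenyl would compare with 2-fluorophenyl at this place. As far as these compounds go, it is also open whether other changes to the shared core, such as replacing the carboxylic acid with an amide, would keep the value of compound 4.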